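The source may hold more compounds than are shown below. What is called first, only, known or untested is meant among the compounds shown, and "the series" means these compounds.

In a functional assay on A549 cells (Homo sapiens) for antiproliferative activity, read by MTT assay, with a stated time of 48 h (on this read-out lower numbers stand for stronger inhibition and higher numbers for weaker inhibition), compound 1 `COc1ccc(/C=C/c2cc(OC)cc(OC)c2/C=C/C(=O)c2ccc(F)cc2)cc1` gives 6.6 ug/mL while compound 2 `CCOc1ccc(C(=O)/C=C/c2c(/C=C/c3ccc(OC)cc3)cc(OC)cc2OC)cc1` gives 7.5 ug/mL and compound 3 `COc1ccc(/C=C/c2cc(OC)cc(OC)c2/C=C/C(=O)c2ccccc2C)cc1` gives 5.9 ug/mL on the same scale. These three values lie within the scatter of one another, so compound 3 stands level with the other two and cannot be ranked apart from them. Compound 4 `COc1ccc(/C=C/c2cc(OC)cc(OC)c2/C=C/C(=O)c2ccc(C)c(C)c2)cc1` keeps the shared core and differs from compound 3 only on the carbonyl carbon, where the change reads 3,4-dimethylphenyl in place of 2-methylphenyl on a carbonyl carbon and puts 3,4-dimethylphenyl in place of 2-methylphenyl. Swaps on that same carbonyl carbon have been measured twice: a 1.1-fold lower number from compound 1 to compound 3 (0.05 log units; within the scatter) and a 1.3-fold lower number from compound 2 to compound 3 (0.10 log units; within the scatter) both stayed within the scatter. The remaining comparison, a 1.1-fold higher number from compound 1 to compound 2 (0.06 log units; within the scatter) on an aromatic carbon, did so as well. Among the compounds with values here, no measured compound carries the 3,4-dimethylphenyl group, so the expectation rests on these neighbouring swaps alone. With all of them this small, no step beyond the scatter is expected in this assay in either direction. The expected step is a 1.1-fold higher number from compound 3 to compound 4 (0.02 log units; within the scatter) and amounts to no real shift. Compound 4 is estimated at 6.2 ug/mL with an expected range from 3.5 ug/mL to 11 ug/mL for the coming measurement.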

Compound 4, half-maximal inhibitory concentration: 0.1 ug/mL
Beside the measured number, compound 4's estimate is 62-fold (1.79 log units) above it, and the stated range ends above it.
By their numbers in this assay, from the lowest: compound 4; then compounds 3, 1 and 2 (each within the scatter of the next).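

On the carbonyl carbon, the earlier swaps had all stayed within the scatter in this assay and gave no sign that the aryl group there mattered, yet putting 3,4-dimethylphenyl in place of 2-methylphenyl gives a 59-fold lower number from compound 3 to compound 4 (1.77 log units; beyond the scatter) and shows that this position can respond strongly. The same group gives a 75-fold lower number from compound 2 to compound 4 (1.88 log units; beyond the scatter) when it replaces 4-ethoxyphenyl and a 66-fold lower number from compound 1 to compound 4 (1.82 log units; beyond the scatter) when it replaces 4-fluorophenyl, so compound 4 is the most potent of the four while the other three stay level with one another. The change adds only one carbon and leaves the counts of hydrogen-bond donors and acceptors and the net charge as they were, and no evidence at hand explains the size of the step.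

The compounds shown leave open whether both methyl groups of 3,4-dimethylphenyl are needed for this result or whether one alone would give it. They also leave open whether an amine or a carboxylic acid on that phenyl ring would keep the activity of compound 4 or return it to the level of the other three.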